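Aryl exchange in a series sitting at the assay limit

This account rests on a few compounds, and the source may have more. Where it says the series, first, only, none or still open, it means among the compounds named here.

Compound 1 `COc1cccc([C@@H](CO)O[C@H]2CCCN(Cc3ccc(C(=O)O)cc3C)[C@H]2c2ccccc2)c1`: in an assay on isolated protein for activation of cGMP-dependent protein kinase 1 (Homo sapiens), read by ADP-Glo, with stated times of 30 min and 2 h (on this read-out lower numbers stand for an effect already at smaller amounts and higher numbers for an effect only at larger amounts of compound), compound 1 gives > 200000 nM, a limit.
Compound 2 `Cc1cc(C(=O)O)ccc1CN1CC[C@H](OC(CO)c2cc(Cl)cc(Cl)c2)[C@@H]1c1ccccc1`: in this assay compound 2 gives 185000 nM.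
Compound 3 `Cc1cc(C(=O)O)ccc1CN1CCC[C@H](O[C@H](CO)c2cc(F)cc(F)c2)[C@@H]1c1ccccc1`: in this assay compound 3 gives > 200000 nM, a limit.

Compound 3 stands at the limit of the assay; only a limit is known for it. The same limit holds for compound 1, and two of the three values sit there (the limit of > 200000 nM in this assay, at which 2 of the 3 values shown sit). Among the measured compounds shown here, the one step that touches compound 3, a step that the two limits leave unreadable from compound 1 to compound 3, lies between two limits and is not readable. Compound 4 `Cc1cc(C(=O)O)ccc1CN1CCC[C@H](O[C@H](CO)c2cc(Cl)nc(Cl)c2)[C@@H]1c1ccccc1` differs from compound 3 by 2,6-dichloropyridin-4-yl in place of 3,5-difluorophenyl on a saturated chain carbon bound to an oxygen on a saturated carbon and a saturated chain carbon. For the measured compounds named here, no measured step bears on this change; all that is known is that the whole series sits at or close to the limit. The step of a number no higher from compound 3 to compound 4 (the limit leaves the size open) is therefore expected to stay within the scatter. Compound 4 is estimated at 200000 nM, between 100000 nM and 400000 nM, most likely again reported as a limit.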

Compound 4, half-maximal effective concentration: > 200000 nM
Compound 4 was reported as a limit (the forecaster's own chance of this, stated with the estimate: 70%); the middle value sits exactly at the limit.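

Among the compounds shown here, compound 1, compound 3 and compound 4 all stand at a limit, so no step among them can be read: the limit of > 200000 nM in this assay, at which 3 of the 4 values shown sit. Left open is whether exchanging these aryl groups changes the read-out at all.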